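A few compounds are considered here, and "the series" means these few. Any claim that something is new, unique, unknown or untested is made for them only; others in the source may bear on it.

Measured so far:
compound 1, `CN1CCN(CCCCCCn2c3c(c4ccccc42)C(=O)c2c[n+]([O-])c4ccccc4c2C3=O)CC1`: 400 nM
compound 2, `O=C1c2c[n+]([O-])c3ccccc3c2C(=O)c2c1c1ccccc1n2Cc1cn([C@@H]2C[C@H](O)[C@@H](CO)O2)nn1`: 110 nM

Both were read in a functional assay on MCF7 cells (Homo sapiens) for cytotoxicity, read by MTT assay, with a stated time of 72 h; a higher number here means a weaker inhibitor, a lower number a stronger inhibitor. Compound 1 gives the higher of the two numbers; the gap down to compound 2 lies beyond the scatter, so compound 2 is the stronger of the pair.

Compound 3, `O=C1c2c[n+]([O-])c3ccccc3c2C(=O)c2c1c1ccccc1n2CCCCN1CCNCC1`, is not yet measured. It differs from compound 1 in one place: piperazin-1-yl in place of 2-(4-methylpiperazin-1-yl)ethyl on a saturated chain carbon, four bonds along the chain from an aromatic nitrogen. Within the data shown here, no measured pair shows this change, so nothing in the numbers fixes its size or direction. The gap between compound 1 and compound 2 concerns a different group on the shared core and carries no weight here.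

With only the two values to go on, the step expected a 1.1-fold lower number from compound 1 to compound 3 (0.06 log units; within the scatter) is small, with no direction beyond the scatter. Compound 3 is therefore estimated at 350 nM in this assay, with a range from 120 nM to 1000 nM.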

Compound 3, half-maximal inhibitory concentration: 12000 nM
Compound 3: the middle estimate sits 34-fold (1.54 log units) below what was measured, and the stated range ends below it.
By their numbers in this assay, from the lowest: compound 2; then compound 1; then compound 3.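

Among these compounds, the step of a 30-fold higher number from compound 1 to compound 3 (1.48 log units; beyond the scatter) in this assay shows that this position is sensitive to the group it carries, which the earlier compounds could not show, as neither gave a step here. Replacing 2-(4-methylpiperazin-1-yl)ethyl with piperazin-1-yl shortens the chain and removes the methyl group from the piperazine ring in one change. The entering group also brings a hydrogen-bond donor, and together these differences go with a large loss of potency in this cell read-out.

No supporting measurement bears on the cause of this step. As far as these compounds go, how the step divides between chain length and the methyl group remains open, and a butyl chain ending in 4-methylpiperazin-1-yl, or a hexyl chain ending in an unsubstituted piperazin-1-yl, would separate the two.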